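7-Substituted nucleosides: cytotoxicity on CEM-DNR-bulk cells

The compounds below may be only part of what the source reports. "The series", "measured", "known", "first", "only" and "open" are said of these compounds alone.

Measured so far:
compound 1 `C#Cc1cn([C@@H]2O[C@H](CO)[C@@H](O)[C@H]2O)c2ncnc(C)c12` — 160 nM
compound 2 `C#Cc1cn([C@@H]2O[C@H](CO)[C@@H](O)[C@H]2O)c2ncnc(N(C)C)c12` — 240 nM

In a functional assay on CEM-DNR-bulk cells (Homo sapiens), read by MTT assay, with a stated time of 72 h (a lower number here means a stronger inhibitor, a higher number a weaker inhibitor), compound 1 gives 160 nM, the lowest of the two numbers; in the same assay compound 2 gives 240 nM, and the step of a 1.5-fold higher number from compound 1 to compound 2 (0.18 log units; within the scatter) lies within the scatter, so the two are not ordered.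

Compound 3 `Cc1ncnc2c1c(-c1cccs1)cn2[C@@H]1O[C@H](CO)[C@@H](O)[C@H]1O` has not yet been measured in this assay. It differs from compound 1 as follows: thiophen-2-yl in place of ethynyl on an aromatic carbon. Among the compounds with values here, the one measured step, from compound 1 to compound 2, concerns a different place on the shared core and a different group, so no measured step bears on the exchange of ethynyl for thiophen-2-yl. Within the data shown here, with no comparable step in hand, the estimate for compound 3 is kept close to compound 1, as a step of a 1.3-fold higher number from compound 1 to compound 3 (0.10 log units; within the scatter) that is expected to stay within the scatter, with a wide range in either direction. Compound 3 is therefore estimated at 200 nM, between 40 nM and 1000 nM.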

Compound 3, half-maximal inhibitory concentration: > 20000 nM
Compound 3 ended at the assay's limit (the forecaster's own chance of this, stated with the estimate: 5%); middle value at least 100-fold (2.00 log units) away from the limit.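

In this assay compound 3 gives > 20000 nM as a limit of the assay and not a number: the limit of > 20000 nM in this assay, at which 1 of the 3 values shown sits.
Within the data shown here, the exchange of ethynyl for thiophen-2-yl gives an at least 120-fold higher number from compound 1 to compound 3 (2.09 log units; beyond the scatter) and lies beyond the scatter, whereas the one earlier exchange, at a different place on the shared core, gave a 1.5-fold higher number from compound 1 to compound 2 (0.18 log units; within the scatter) and stayed within it.
This aromatic carbon, two ring bonds from the ring nitrogen, is thus the first place in the series where a single exchange carries the value to the limit of the assay.

With only ethynyl and thiophen-2-yl on this carbon, no trend across groups can be drawn, and how far compound 3 lies beyond its limit cannot be read.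
Going by these compounds, how an amine, a phenyl ring or a longer alkynyl chain on this carbon would read remains open.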